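The source may hold more compounds than are shown below. What is called first, only, known or untested is meant among the compounds shown, and "the series" means these compounds.

Series notes. Within the data shown here, compound 1 `COc1ccccc1-n1nc([C@H]2C[C@@H](C)O[C@@H](C)C2)cc1-c1ccc(Cl)cc1` gives in an assay on HEK293 cells for inhibition of Voltage-dependent N-type calcium channel subunit alpha-1B (Homo sapiens), read by patch clamp, using a membrane potential dye (a higher number here means a weaker inhibitor, a lower number a stronger inhibitor), a value of 12 nM, the lower of the two numbers so far. Compound 2 `COc1ccccc1-n1nc(C2CC(C)(C)OC(C)(C)C2)cc1-c1ccc(C)nc1` gives 13000 nM in this assay; it differs from compound 1 in two places, so the gap cannot be assigned to either change alone. Compound 3 `COc1ccccc1-n1nc([C@@H]2CCO[C@H](C(C)C)C2)cc1-c1ccc(Cl)cc1` is not yet measured and differs from compound 1 by 2-isopropyloxan-4-yl in place of 2,6-dimethyloxan-4-yl on an aromatic carbon. Among the measured compounds shown here, no measured pair isolates this change. For compound 3 the expected step is a 2.5-fold higher number from compound 1 to compound 3 (0.40 log units; beyond the scatter), a mild weakening not clearly beyond the scatter. Compound 3 is estimated at 30 nM, within a range from 8 nM to 120 nM.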

Compound 3, half-maximal inhibitory concentration: 55000 nM
Compound 3: middle estimate off by 1800-fold (3.26 log units), on the low side; measured number outside the range, above it.
By their numbers in this assay, from the lowest: compound 1; then compound 2; then compound 3.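

On the aromatic carbon of the five-membered ring, 2-isopropyloxan-4-yl in place of 2,6-dimethyloxan-4-yl gives a 4600-fold higher number from compound 1 to compound 3 (3.66 log units; beyond the scatter) in this assay. Ring size, hydrogen-bond acceptor count and charge stay the same and the group goes only from 8 to 9 heavy atoms, so at this position a small change in the substituents on the oxane ring carries a large step. Nothing on hand accounts for this step.

The compounds shown leave open whether the isopropyl group, the absent second methyl or the different stereocentres decide the outcome. Going by these compounds, how an unsubstituted oxan-4-yl or a 2-ethyloxan-4-yl would read here also remains open.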